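Dropping the ring methyl from an anilino thiazole chalcone

A few compounds are considered here, and "the series" means these few. Any claim that something is new, unique, unknown or untested is made for them only; others in the source may bear on it.

Measured compounds:
- compound 1 `Cc1nc(Nc2ccc(Cl)cc2)sc1C(=O)/C=C/c1ccccc1` gives 24600 nM in a functional assay on PC-3 cells (Homo sapiens) for cytotoxicity, read by MTT assay; a lower number here means a stronger inhibitor, a higher number a weaker inhibitor
- compound 2 `Cc1ccccc1Nc1nc(C)c(C(=O)/C=C/c2ccccc2)s1` gives > 25000 nM in this assay

The value shown for compound 2 is a limit of this assay, not a number, so compound 2 stands only at the weak end of what this assay can report. Compound 1 sits close to that same edge. Within the data shown here, the single comparison available, an at least 1.0-fold higher number from compound 1 to compound 2 (0.00 log units; that floor lies within the scatter), shows no step beyond the usual scatter between the two.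

Compound 3 `Cc1nc(Nc2ccccc2)sc1C(=O)/C=C/c1ccccc1` differs from compound 2 in one place: hydrogen in place of methyl on an aromatic carbon. Among the measured compounds shown here, the only step measured, from compound 1 to compound 2, swapped one substituted phenyl on that nitrogen for another and moved nothing; the change to compound 3 is smaller still, a loss of a single methyl on the same phenyl. Both measured neighbours lie at or next to the limit of > 25000 nM in this assay, at which 1 of the 2 values shown sits, so there is little room for the number to move, and no step beyond the scatter is expected in either direction. Compound 3 is therefore estimated at 25000 nM, with a range from 8000 nM to 70000 nM. That estimate corresponds to an expected step of a number no higher from compound 2 to compound 3 (the limit leaves the size open), and it is quite likely that compound 3 also returns only a limit.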

Compound 3, half-maximal inhibitory concentration: > 25000 nM
Compound 3: a limit, no number; the forecaster's own chance of this, stated with the estimate: 60%; the middle value sits exactly at the limit.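

In this assay compound 3 gives > 25000 nM as well, which is a limit and not a number. The phenyl with no substituent at all therefore ends up at the same weak edge as the 2-methylphenyl, so taking the methyl away from the aromatic carbon does not bring the series into the range where this assay gives a number. Taking the chloro group away instead leaves an at least 1.0-fold higher number from compound 1 to compound 3 (0.00 log units; that floor lies within the scatter) and no clear change, while the step for losing the methyl cannot be read, because both of its ends are limits: the limit of > 25000 nM in this assay, at which 2 of the 3 values shown sit.

The compounds shown leave open whether anything placed on this phenyl can bring the number clearly down, since the three groups compared so far stay together at the weak edge. A methoxy group or an amine on that ring, or a carboxylic acid, might give a value well inside the range of this assay, and only such a value would make a real comparison possible at this position.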